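The source may hold more compounds than are shown below. What is called first, only, known or untested is meant among the compounds shown, and "the series" means these compounds.

Measured so far in a functional assay on MT4 cells (Homo sapiens) for cytotoxicity, with a stated time of 4 days; on this read-out higher numbers stand for lower toxicity in this test and lower numbers for higher toxicity in this test:
Compound 1 `OCCSCc1ncnc2c1ncn2[C@@H]1O[C@H](CO)[C@@H](O)[C@H]1O` gives > 100000 nM, a limit of the assay.
Compound 2 `CC(=O)N(Cc1ncnc2c1ncn2[C@H]1C[C@H](O)[C@@H](CO)O1)C1CCCCC1` gives > 100000 nM, also a limit of the assay.

Among the measured compounds shown here, compound 1 thus stands at the upper edge of what this assay reports: its value is a limit rather than a number, and the same holds for the only other measured compound, as the limit of > 100000 nM in this assay, at which 2 of the 2 values shown sit, notes. For the measured compounds named here, no comparison between measured compounds can therefore be sized here; the two values show only that neither reached a measurable half-maximal cytotoxic concentration.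

Compound 3 `OC[C@H]1O[C@@H](n2cnc3c(Cn4cccn4)ncnc32)[C@H](O)[C@@H]1O` has not yet been measured. It differs from compound 1 by 1H-pyrazol-1-yl in place of (2-hydroxyethyl)sulfanyl on a saturated chain carbon bound to an aromatic carbon. Going by the values given here, with both known values sitting at the limit, no step between them beyond the scatter is expected, and the most likely outcome is that compound 3 again returns only a limit. Compound 3 is expected to give 100000 nM, within 30000 nM to 300000 nM, which amounts to an expected step of a number no higher from compound 1 to compound 3 (the limit leaves the size open).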

Compound 3, half-maximal cytotoxic concentration: 48000 nM
Compound 3: middle estimate off by 2.1-fold (0.32 log units), on the high side; low and high end bracket the measured number.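

Compound 3 is the only compound shown that gives a measured number rather than a limit in this assay, so a change on a saturated chain carbon bound to an aromatic carbon can move this read-out. Putting 1H-pyrazol-1-yl in place of (2-hydroxyethyl)sulfanyl gives an at least 2.0-fold lower number from compound 1 to compound 3 (0.31 log units; beyond the scatter), a shift towards higher toxicity in this test. Only a lower bound can be given for the size of this step, because the starting value is not a number: the limit of > 100000 nM in this assay, at which 2 of the 3 values shown sit.

The compounds shown do not separate the arrival of the aromatic ring from the loss of the sulfur atom or the hydroxyl group. They also leave open how an amine, a carboxylic acid or a longer chain in this place would read in this assay.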